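The source may report more compounds than this note shows. Statements on the series, on what has been measured and on what is new or still open speak of the compounds shown alone.

In a functional assay on the whole organism (strain Sprague-Dawley) for inhibition, with Rattus norvegicus as the target (on this read-out higher numbers stand for an effect only at larger amounts of compound and lower numbers for an effect already at smaller amounts), compound 1 `O=c1c(-c2nn[nH]n2)c[nH]c2c(F)cccc12` gives 10 mg/kg. Compound 2 `Cc1cc(F)c2[nH]cc(-c3nn[nH]n3)c(=O)c2c1` returns only a limit in this assay, > 10 mg/kg. The change from compound 1 to compound 2 is methyl in place of hydrogen on an aromatic carbon, and the step of a number no lower from compound 1 to compound 2 (the limit leaves the size open) is known only as a number no lower, its size left open by the limit (the limit of > 10 mg/kg in this assay, at which 1 of the 3 values shown sits). Compound 3 `c1ccc2ncc(-c3nn[nH]n3)cc2c1` gives 25 mg/kg in this assay, the highest of the two numbers recorded, and the difference between its core and the core of compound 1 is not broken down here. Compound 4 `Cc1cccc2cc(-c3nn[nH]n3)cnc12` has not yet been measured. It differs from compound 3 by methyl in place of hydrogen on an aromatic carbon, the same kind of change as that from compound 1 to compound 2, though here the methyl sits ortho to a fused ring and meta to a fused ring, whereas in compound 2 it sits meta to a fluoro group, meta to a fused ring and para to a fused ring. Compound 4 is expected to shift by a 1.2-fold higher number from compound 3 to compound 4 (0.08 log units; within the scatter), an expectation that rests on the measured step of a number no lower from compound 1 to compound 2 (the limit leaves the size open). Compound 4 is therefore estimated at 30 mg/kg, expected to lie between 10 mg/kg and 100 mg/kg.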

Compound 4, minimum effective dose: 25 mg/kg
The estimate for compound 4 lay 1.2-fold (0.08 log units) above the measured number, within the range that was stated.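

In this assay, methyl in place of hydrogen on an aromatic carbon, ortho to a fused ring and meta to a fused ring, brings no change at the digits printed from compound 3 to compound 4 (within the scatter), so on this core the change leaves no mark on the minimum effective dose. Set beside the earlier step, the picture across the two cores is this: the same change on two cores in this assay, a number no lower (the limit leaves the size open) from compound 1 to compound 2 and no change at the digits printed (within the scatter) from compound 3 to compound 4; the limit leaves it open whether they differ. Compound 2 returns only a limit, and the data therefore show neither that the change carries from one core to the other nor that it fails to carry, as the earlier step has no size against which the new one could be held: the limit of > 10 mg/kg in this assay, at which 1 of the 4 values shown sits.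

The compounds shown leave open whether a group other than methyl, such as an ethyl chain, a methoxy group or an amine, would move the number on either core. They also leave open what methyl would do on the other aromatic carbons of the core shared by compound 3 and compound 4.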